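The source may hold more compounds than are shown below. What is called first, only, known or untested is meant among the compounds shown, and "the series" means these compounds.

Measured in an ADME assay on L1210 cells (Mus musculus) for cytotoxicity, with a stated time of 48 h; on this read-out higher numbers stand for weaker inhibition and lower numbers for stronger inhibition:
- compound 1 `CC1=CCC[C@](C)(CC/C(C)=C/CC2=C(O)C(=O)C=C(N[C@H](C(=O)O)[C@@H](C)O)C2=O)[C@@H]1C`: > 10 ug/mL, a limit
- compound 2 `CC1=CCC[C@](C)(CC/C(C)=C/CC2=C(O)C(=O)C=C(N[C@H](C(=O)O)[C@H](C)O)C2=O)[C@@H]1C`: > 10 ug/mL, a limit

Compound 2 stands only at a limit, > 10 ug/mL, and has no numerical value. The same holds for its partner in the series, as the limit of > 10 ug/mL in this assay, at which 2 of the 2 values shown sit, shows.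

The next step runs from compound 2 to compound 3 `CC1=CCC[C@](C)(CC/C(C)=C/CC2=C(O)C(=O)C=C(N[C@H](C(=O)O)C(C)C)C2=O)[C@@H]1C`, which carries isopropyl in place of 1-hydroxyethyl on a saturated chain carbon bound to an amine nitrogen and a carbonyl carbon.

Among the compounds with values here, only one measured step bears on this change, and only loosely: a step that the two limits leave unreadable from compound 1 to compound 2. That step alters configuration alone (the fact that compounds 1 and 2 differ only in the configuration as drawn), so it does not test removal of the 1-hydroxyethyl group, and it has no readable size. No direction can therefore be carried over to this assay, and no large step is expected. A further limit reading is the likeliest outcome.

The expected change is a step that the limit leaves unreadable from compound 2 to compound 3. For compound 3 the estimated value is 12 ug/mL, with an expected range of 4 ug/mL to 30 ug/mL.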

Compound 3, half-maximal inhibitory concentration: 3.4 ug/mL
Estimate against measurement, compound 3: 3.5-fold (0.55 log units) above; measured number below the stated range.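

In this assay, isopropyl in place of 1-hydroxyethyl on a saturated chain carbon bound to an amine nitrogen and a carbonyl carbon gives an at least 2.9-fold lower number from compound 2 to compound 3 (0.46 log units; beyond the scatter) and also an at least 2.9-fold lower number from compound 1 to compound 3 (0.46 log units; beyond the scatter). Within the data shown here, compound 3 gives 3.4 ug/mL, the first reading that is a number and not a limit, so the read-out at this position does respond to the group placed there, and it does so from either hydroxylated partner. The earlier pair could not show this, as its single step cannot be read and involves no change of group: the fact that compounds 1 and 2 differ only in the configuration as drawn

The compounds shown leave open how the number moves with other groups at this position, such as a longer chain like isobutyl, a benzyl group, or a side chain ending in an amine or a carboxylic acid, so a single exchange marks no trend. Also open, on these data alone, are whether the configuration of the saturated chain carbon bound to the amine nitrogen and the carbonyl carbon matters once isopropyl is in place, and whether a smaller group such as methyl keeps the lower number.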